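The source may hold more compounds than are shown below. What is called first, only, known or untested is meant among the compounds shown, and "the series" means these compounds.

Measured in a functional assay on U-87MG ATCC cells (Homo sapiens) for antiproliferative activity; on this read-out higher numbers stand for weaker inhibition and lower numbers for stronger inhibition:
- compound 1 `Cc1c2c(n3c1CCN(C)C[C@@H](C)[C@H](C)Nc1cc-3ccc1C(N)=O)CC(C)(C)CC2=O`: 49 nM
- compound 2 `CC(=O)N1CCCc2c(C)c3c(n2-c2ccc(C(N)=O)c(c2)N[C@@H](C)[C@@H]1C)CC(C)(C)CC3=O`: 29 nM

Compound 1 stands within the scatter of compound 2, so the two values do not separate. Compound 3 `Cc1c2c(n3c1CCN(C(=O)C(C)(C)N)C[C@@H](C)[C@H](C)Nc1cc-3ccc1C(N)=O)CC(C)(C)CC2=O` has (1-amino-1-methylethyl)carbonyl in place of methyl on an amine nitrogen in a ring of the core of compound 1: (1-amino-1-methylethyl)carbonyl in place of methyl on an amine nitrogen in a ring. Among the compounds with values here, no measured step covers this change, so the direction is open and no step beyond the scatter is expected in this assay. The expected change is a 1.4-fold lower number from compound 1 to compound 3 (0.15 log units; within the scatter). For compound 3 the estimated value is 35 nM, with an expected range of 10 nM to 120 nM.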

Compound 3, half-maximal inhibitory concentration: 39 nM
The estimate for compound 3 lay 1.1-fold (0.05 log units) below the measured number; measured number inside the range.
By their numbers in this assay, from the lowest: compounds 2, 3 and 1 (each within the scatter of the next).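

In this assay, replacing methyl with (1-amino-1-methylethyl)carbonyl on the amine nitrogen in a ring gives a 1.3-fold lower number from compound 1 to compound 3 (0.10 log units; within the scatter) and so does not separate the two compounds. The earlier compounds shown here gave no step at this position; this one shows that the nitrogen can carry this larger acylated group, with its added hydrogen-bond donor and acceptors, and the value stays within the scatter. Nothing on hand gives a reason for this result.

Whether the free amine of the new group matters remains open, since no matching group without that amine is shown. Going by these compounds, it is also open whether a carboxylic acid or a longer chain on this nitrogen would stay within the scatter.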